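A few compounds are considered here, and "the series" means these few. Any claim that something is new, unique, unknown or untested is made for them only; others in the source may bear on it.

- Compound 1 `Cc1ccc(S(=O)(=O)NC(=O)c2cccnc2)cc1` gives 18500 nM
- Compound 2 `O=C(NS(=O)(=O)c1ccc(Cl)cc1)c1cncc(C(=O)NS(=O)(=O)c2ccc(Cl)cc2)c1` gives 10600 nM

In a functional assay on B16-F10 cells (Mus musculus) for antiproliferative activity, read by colorimetric assay and MTT assay, with a stated time of 48 h (a lower number here means a stronger inhibitor, a higher number a weaker inhibitor), compound 1 lies within the usual scatter of compound 2, its only measured comparator, so the two cannot be ranked against each other. Compound 3 `Cc1ccc(S(=O)(=O)NC(=O)c2ccccn2)cc1` has the same atoms as compound 1, joined differently (pyridin-2-yl in place of pyridin-3-yl on a carbonyl carbon), with pyridin-2-yl in place of pyridin-3-yl on a carbonyl carbon. Among the compounds with values here, no measured pair shows what a change of this kind does, so no step beyond the scatter is expected, in either direction. The expectation therefore rests on compound 1 at 18500 nM and not on any trend. An estimated step of a 1.0-fold lower number from compound 1 to compound 3 (0.01 log units; within the scatter) is expected to stay within the scatter. Compound 3 is expected at 18000 nM with an estimated range from 8000 nM to 40000 nM in this measurement.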

Compound 3, half-maximal inhibitory concentration: 16700 nM
Compound 3: middle estimate off by 1.1-fold (0.03 log units), on the high side; the range from low to high includes it.
By their numbers in this assay, from the lowest: compounds 2, 3 and 1 (each within the scatter of the next).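

In this assay, pyridin-2-yl in place of pyridin-3-yl on a carbonyl carbon gives a 1.1-fold lower number from compound 1 to compound 3 (0.04 log units; within the scatter), a step within the scatter. This pair is the only one shown that differs in one place, and it shows that this change at this position produces no difference the assay can resolve, which compound 1 and compound 2 alone could not show. No measured evidence bears on why the two compounds read alike.

From the compounds shown here alone, whether a phenyl group or a longer chain on the same carbonyl carbon would also stay within the scatter remains open. So does whether any single change to the core of compound 1 would move the number beyond the scatter, as the values shown each lie within the scatter of the next.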